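Butylsulfinyl in place of ethyl on the shared core

This account rests on a few compounds, and the source may have more. Where it says the series, first, only, none or still open, it means among the compounds named here.

Measured so far:
compound 1, `Cc1nc(N)c2nc(O)n(Cc3ccccc3)c2n1`: 3 mg/kg
compound 2, `CCc1nc(N)c2nc(O)n(Cc3ccccc3)c2n1`: 3 mg/kg

In a functional assay on the whole organism for activation, with Mus musculus as the target (a lower number here means that less compound is needed, a higher number that more compound is needed for the effect), compound 2 gives 3 mg/kg and stands level with compound 1, which gives 3 mg/kg; the step of no change at the digits printed from compound 1 to compound 2 (within the scatter) lies within the scatter. Compound 3, `CCCC[S+]([O-])c1nc(N)c2nc(O)n(Cc3ccccc3)c2n1`, is not yet measured. It differs from compound 2 by a group of 6 heavy atoms (4 carbon, 1 oxygen, 1 sulfur; no ring) in place of a group of 2 heavy atoms (2 carbon; no ring), on an aromatic carbon. Among the compounds with values here, the one measured step that touches the same aromatic carbon is no change at the digits printed from compound 1 to compound 2 (within the scatter), a methyl in place of hydrogen on a saturated chain carbon bound to that aromatic carbon, which left this assay unchanged. That step is far smaller than the present one, so it bears on it only weakly. Nothing measured shows how a six-heavy-atom group carrying one hydrogen-bond acceptor is tolerated at this carbon. With only a small, flat step to lean on, compound 3 is expected at 3 mg/kg, with a range of 1 mg/kg to 15 mg/kg; this estimate means no change at the digits printed from compound 2 to compound 3 (within the scatter), no step beyond the scatter expected, but with wide uncertainty.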

Compound 3, minimum effective dose: 1 mg/kg
The estimate for compound 3 lay 3.0-fold (0.48 log units) above the measured number, within the range that was stated.
By their numbers in this assay, from the lowest: compound 3; then compounds 1 and 2 (each within the scatter of the next).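

In this assay the aromatic carbon between two ring nitrogen atoms now shows a response beyond the scatter, with butylsulfinyl giving a 3.0-fold lower number from compound 2 to compound 3 (0.48 log units; beyond the scatter) and, against the smaller group, a 3.0-fold lower number from compound 1 to compound 3 (0.48 log units; beyond the scatter). The earlier step at this carbon was flat, so it could not show that a group of 6 heavy atoms carrying a hydrogen-bond acceptor is accepted here, with less compound needed for the effect. No evidence bears on the reason for this lower number.

Still open, on these data alone, is whether the step follows the butyl chain itself or the sulfinyl group, a question that plain butyl or butylthio at this carbon would address. Also open, as far as these compounds go, is how butylsulfonyl, a shorter ethylsulfinyl or an amine would behave at the same carbon.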